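This account rests on a few compounds, and the source may have more. Where it says the series, first, only, none or still open, it means among the compounds named here.

Compound 1 `COc1cc2ncnc(Nc3ccc(Br)cc3)c2cc1OCCCCC(=O)Nc1ccc(S(N)(=O)=O)cc1`: 6570 nM
Compound 2 `COc1cc2ncnc(Nc3ccc(C(F)(F)F)cc3)c2cc1OCCCCC(=O)Nc1ccc(S(N)(=O)=O)cc1`: 16900 nM

In a functional assay on A-431 cells (Homo sapiens) for antiproliferative activity, read by MTT assay, with a stated time of 72 h (on this read-out higher numbers stand for weaker inhibition and lower numbers for stronger inhibition), compound 2 gives 16900 nM, the highest of the two numbers measured; the nearest is compound 1 with 6570 nM, a difference that lies beyond the scatter. Compound 3 `COc1cc2ncnc(Nc3ccc(C)cc3)c2cc1OCCCCC(=O)Nc1ccc(S(N)(=O)=O)cc1` differs from compound 2 by methyl in place of trifluoromethyl on an aromatic carbon. Among the measured compounds shown here, only one measured step bears on this change: a 2.6-fold higher number from compound 1 to compound 2 (0.41 log units; beyond the scatter), which shows that exchanging the group on this aromatic carbon shifts the number modestly but beyond the scatter. With methyl in place of trifluoromethyl, a shift of similar size back toward the number of compound 1 is expected, because a 2.6-fold higher number from compound 1 to compound 2 (0.41 log units; beyond the scatter) showed the number rising when trifluoromethyl entered. Compound 3 is therefore expected to show a 2.1-fold lower number from compound 2 to compound 3 (0.32 log units; beyond the scatter), a lower number than compound 2. For compound 3 the estimate in this assay is 8000 nM, with a range from 3000 nM to 25000 nM.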

Compound 3, half-maximal inhibitory concentration: 35500 nM
For compound 3 the middle estimate is 4.4-fold (0.65 log units) below the measured one; the measured number lies above the stated range.
By their numbers in this assay, from the lowest: compound 1; then compound 2; then compound 3.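

In this assay, replacing trifluoromethyl with methyl gives a 2.1-fold higher number from compound 2 to compound 3 (0.32 log units; beyond the scatter), so this change raises the number further rather than taking it back toward that of compound 1. Replacing bromo with methyl gives a 5.4-fold higher number from compound 1 to compound 3 (0.73 log units; beyond the scatter), so across the three groups tried at this position, bromo in compound 1 gives the strongest inhibition and methyl in compound 3 the weakest, with trifluoromethyl in compound 2 in the middle. Nothing here explains why the groups fall in this order.

From the compounds shown here alone, it remains open whether a chloro group, a methoxy group or an amine on this aromatic carbon would fit the same order or give a number lower than that of compound 1. Going by these compounds, it is also open whether the order would hold with a shorter chain joining the shared core to the amide.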